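The source may hold more compounds than are shown below. What is called first, only, known or untested is meant among the compounds shown, and "the series" means these compounds.

The measured compounds and their values:

compound 1, `O=c1c(C(=S)Nc2ccccc2)coc2cc(Cl)ccc12`: 55% in a functional assay on PC-3 cells (Homo sapiens) for inhibition, read by sulforhodamine B assay, with a stated time of 48 h, tested at 100 uM; a higher number here means more inhibition of growth at the concentration tested, a lower number less inhibition of growth
compound 2, `O=c1c(C2N=C(c3ccccc3)SS2)coc2cc(Cl)ccc12`: 81% in this assay
compound 3, `O=c1c(C2N=C(c3ccccc3)SS2)coc2ccccc12`: 23% in this assay

Compound 2 and compound 3 share one core, and compound 1 carries a different one; the difference between the two cores is not broken down here. From compound 2 to compound 3 the change is hydrogen in place of chloro on an aromatic carbon, and it gave a number 58 percentage points lower from compound 2 to compound 3 (beyond the scatter). Compound 1 stands between those two values in this assay.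

The unmeasured compound 4, `O=c1c(C(=S)Nc2ccccc2)coc2ccccc12`, is related to compound 1 in the same way: the change is hydrogen in place of chloro on an aromatic carbon, at a place described in exactly the same words as for compound 2 and compound 3, so it is the same change made on a different core.

A downward step is expected from compound 1 to compound 4, namely a number 40 percentage points lower from compound 1 to compound 4 (beyond the scatter), resting on the step of a number 58 percentage points lower from compound 2 to compound 3 (beyond the scatter); because compound 1 starts at 55%, the fall cannot be as deep. For compound 4 the expected value in this assay is 15%, estimated between 0% and 45%.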

Compound 4, percent growth inhibition at one concentration: 63%
The estimate for compound 4 lay 48 percentage points below the measured number; measured number outside the range, above it.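

Hydrogen in place of chloro on an aromatic carbon did not repeat its earlier effect on the core of compound 1: in this assay it gave a number 8 percentage points higher from compound 1 to compound 4 (within the scatter), so no change can be read on this core, whereas a number 58 percentage points lower from compound 2 to compound 3 (beyond the scatter). Set side by side, the same change therefore depends on the core it is made on: the same change on two cores in this assay, a number 58 percentage points lower (beyond the scatter) from compound 2 to compound 3 and a number 8 percentage points higher (within the scatter) from compound 1 to compound 4, 66 percentage points apart, beyond the scatter of two such steps. Among the compounds shown here, this does not show why the two cores part, and with only one pair on each core, read at a single concentration, it gives no rule for any further core.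

The compounds shown leave open whether a different group on that aromatic carbon, such as fluoro, bromo, methoxy or an amine, would matter on one core and not on the other. They also leave open whether a carboxylic acid or a longer chain on the phenyl ring of either core would alter how much the chloro counts.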